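Moving the Methyl Along the Aryl Ring

The source may report more compounds than this note shows. Statements on the series, on what has been measured and on what is new or still open speak of the compounds shown alone.

Compound 3 `CCOC(=O)c1c(-c2ccccc2C)[nH]c2cc(OC)ccc2c1=O` has been tested in a physicochemical assay for solubility, in phosphate buffer, at pH 7.4; on this read-out lower numbers stand for lower solubility and higher numbers for higher solubility. In this assay compound 3 gives > 100000 nM, which is a limit of the assay and not a number. Compound 1 `CCOC(=O)c1c(-c2cccc(Cl)c2)[nH]c2cccc(OC)c2c1=O` likewise gives > 100000 nM, again a limit rather than a number. Among the measured compounds shown here, compound 2 `CCOC(=O)c1c(-c2cccc(C(F)(F)F)c2)[nH]c2cc(OC)ccc2c1=O` is the one compound of the three that gives a number, 19000 nM. Compound 3 therefore stands at the upper edge of what this assay can report, a position it shares with compound 1 (the limit of > 100000 nM in this assay, at which 2 of the 3 values shown sit).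

Compound 4 `CCOC(=O)c1c(-c2cccc(C)c2)[nH]c2cc(OC)ccc2c1=O` has not yet been measured. It differs from compound 3 in one place (3-methylphenyl in place of 2-methylphenyl on an aromatic carbon). For the measured compounds named here, no measured pair among the three shows this same change, so the size of the step has no direct precedent here. Going by the values given here, compound 2, the only compound with a number, points to the possibility that compounds of this shared core can fall clearly below the limit. Compound 4 is expected to show a step of an at least 2.5-fold lower number from compound 3 to compound 4 (0.39 log units; beyond the scatter) downward, beyond the usual scatter. The estimate for compound 4 is 40000 nM, within a range from 10000 nM to 100000 nM.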

Compound 4, solubility: 48000 nM
The estimate for compound 4 lay 1.2-fold (0.08 log units) below the measured number; measured number inside the range.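

In this assay, the change from 2-methylphenyl to 3-methylphenyl gives the first step read for this position, an at least 2.0-fold lower number from compound 3 to compound 4 (0.31 log units; beyond the scatter) and thus beyond the scatter, although the atoms stay the same and are only joined differently. The value of compound 3 is a limit and not a number, so this step has a minimum size and no exact size: the limit of > 100000 nM in this assay, at which 2 of the 4 values shown sit. Methyl in place of trifluoromethyl on the same aromatic carbon gives a 2.5-fold higher number from compound 2 to compound 4 (0.40 log units; beyond the scatter) and is also beyond the scatter, so the group carried on this phenyl ring matters as well as where the methyl sits.

From the compounds shown here alone, whether an amine or a carboxylic acid in place of the methyl would shift the number further remains open. Going by these compounds, it is also open whether moving the methyl has the same effect on the core of compound 1.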